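Three five-membered and six-membered rings, one more to come

The source may hold more compounds than are shown below. What is called first, only, known or untested is meant among the compounds shown, and "the series" means these compounds.

Measured so far:
compound 1 `OC[C@H]1OC(n2cnc3c(-c4ccco4)ncnc32)[C@H](O)[C@@H]1O` gives 600 nM
compound 2 `OC[C@H]1OC(n2cnc3c(-c4cc[nH]c4)ncnc32)[C@H](O)[C@@H]1O` gives 1030 nM
compound 3 `OC[C@H]1OC(n2cnc3c(-c4ccccn4)ncnc32)[C@H](O)[C@@H]1O` gives 900 nM

All three numbers come from a functional assay on CCRF-CEM cells (Homo sapiens) for inhibition; on this read-out higher numbers stand for weaker inhibition and lower numbers for stronger inhibition. Compound 2 holds the highest of the three, but its neighbours are close: the step of a 1.7-fold higher number from compound 1 to compound 2 (0.23 log units; within the scatter) is within the scatter, and so is the step of a 1.1-fold lower number from compound 2 to compound 3 (0.06 log units; within the scatter). The step of a 1.5-fold higher number from compound 1 to compound 3 (0.18 log units; within the scatter) is within the scatter as well. So the three measured compounds cannot be told apart on this assay.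

Compound 4 `Cc1ccsc1-c1ncnc2c1ncn2C1O[C@H](CO)[C@@H](O)[C@H]1O` is the next one. Its change from compound 2 is 3-methylthiophen-2-yl in place of 1H-pyrrol-3-yl on an aromatic carbon. Among the measured compounds shown here, none of the measured steps makes exactly this exchange; the nearest are the exchanges of the pyrrole ring for a furan ring and for a pyridine ring, both within the scatter. With every exchange at this aromatic carbon so far leaving the number where it was, compound 4 is expected to stay in the same band, at 700 nM with a range from 250 nM to 2000 nM. The step of a 1.5-fold lower number from compound 2 to compound 4 (0.17 log units; within the scatter) is thus expected to lie within the scatter, with the direction undecided.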

Compound 4, half-maximal inhibitory concentration: 2500 nM
For compound 4 the middle estimate is 3.6-fold (0.55 log units) below the measured one; measured number above the stated range.
By their numbers in this assay, from the lowest: compounds 1, 3 and 2 (each within the scatter of the next); then compound 4.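

Among the compounds shown here, at this aromatic carbon, 3-methylthiophen-2-yl is the first group to move the number beyond the scatter in this assay, toward weaker inhibition: the steps are a 2.4-fold higher number from compound 2 to compound 4 (0.39 log units; beyond the scatter) and a 2.8-fold higher number from compound 3 to compound 4 (0.44 log units; beyond the scatter) and also a 4.2-fold higher number from compound 1 to compound 4 (0.62 log units; beyond the scatter) in the same direction. The position therefore does not treat all aromatic rings alike, since the furan-2-yl, 1H-pyrrol-3-yl and pyridin-2-yl compounds cannot be told apart while compound 4 stands apart from all three. Nothing shown here gives a reason for this modest loss.

The compounds shown do not separate the contribution of the methyl group from that of the thiophene ring, since both enter together in compound 4. As far as these compounds go, it also remains open how an amine, a carboxylic acid or a longer alkyl chain on this carbon would read out.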